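From Benzamide to Methoxyphenyl Urea in an Antiproliferative Series

A few compounds are considered here, and "the series" means these few. Any claim that something is new, unique, unknown or untested is made for them only; others in the source may bear on it.

Compound 1 `O=C(Nc1cccc(-c2nc(-c3ccc(NC(=O)c4cccnc4)cc3Cl)no2)c1)c1ccccc1` is the weaker of the two measured compounds in a functional assay on MDA-MB-231 cells (Homo sapiens) for antiproliferative activity, read by MTT assay, with a stated time of 72 h (a higher number here means a weaker inhibitor, a lower number a stronger inhibitor), where compound 1 gives 12800 nM. Compound 2 `O=C(Nc1ccc(-c2noc(-c3cccc(NS(=O)(=O)c4ccc(NC(=O)N5CCCC5)cc4)c3)n2)c(Cl)c1)c1cccnc1`, which rearranges similar pieces around a related core, gives 5800 nM in this assay, a number that sits beyond the usual scatter from that of compound 1. Compound 3 `COc1cccc(NC(=O)Nc2cccc(-c3nc(-c4ccc(NC(=O)c5cccnc5)cc4Cl)no3)c2)c1` has not yet been measured. It differs from compound 1 in one place: (3-methoxyphenyl)amino in place of phenyl on a carbonyl carbon. Going by the values given here, no pair of measured compounds isolates this single change, so the two values shown are all there is to lean on. The expectation is therefore a modest step from compound 1 to compound 3, a 1.5-fold lower number from compound 1 to compound 3 (0.18 log units; within the scatter), a slight move toward a stronger inhibitor but not clearly beyond the scatter. Compound 3 is estimated at 8500 nM, with a range from 3000 nM to 25000 nM.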

Compound 3, half-maximal inhibitory concentration: 6700 nM
For compound 3 the middle estimate is 1.3-fold (0.10 log units) above the measured one, within the range that was stated.
By their numbers in this assay, from the lowest: compounds 2, 3 and 1 (each within the scatter of the next, the first and the last beyond it).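

At this position, on the carbonyl carbon, (3-methoxyphenyl)amino in place of phenyl gives a 1.9-fold lower number from compound 1 to compound 3 (0.28 log units; within the scatter) in this assay and turns benzamido into ((3-methoxyphenyl)carbamoyl)amino. The position therefore accepts a larger group that brings a hydrogen-bond donor and a hydrogen-bond acceptor, with no shift that can be told apart from the ordinary variation between repeated measurements. No measurement shown offers an explanation for this result.

Because the amino link and the methoxy group enter together, the compounds shown cannot separate what each contributes. As far as these compounds go, a plain phenylamino group would test the link without the methoxy group, while a 3-methoxyphenyl group placed directly on the carbonyl carbon would test the methoxy group without the link, and how either would read remains open.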